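Replacing dimethylamino with bromo on an aromatic carbon

The source may hold more compounds than are shown below. What is called first, only, known or untested is meant among the compounds shown, and "the series" means these compounds.

In a functional assay on A549 cells (Homo sapiens) for inhibition, read by MTT assay, with a stated time of 48 h (on this read-out lower numbers stand for stronger inhibition and higher numbers for weaker inhibition), compound 1 `COc1ccc(C(c2c[nH]c3ccc(Br)cc23)c2c[nH]c3ccc(Br)cc23)cc1` gives 10000 nM and compound 2 `COc1ccc(C(c2c[nH]c3ccc(Br)cc23)c2c[nH]c3ccc(Br)cc23)cc1OC` gives 12000 nM; the step is a 1.2-fold higher number from compound 1 to compound 2 (0.08 log units; within the scatter). Compound 3 `CN(C)c1ccc(C(c2c[nH]c3ccc(Br)cc23)c2c[nH]c3ccc(Br)cc23)cc1` gives 25000 nM, the highest number of the three and so the weakest inhibitor measured here. Among the measured compounds shown here, compound 4 `Brc1ccc(C(c2c[nH]c3ccc(Br)cc23)c2c[nH]c3ccc(Br)cc23)cc1` has no measurement yet. It carries bromo in place of dimethylamino on an aromatic carbon, para to a large group: bromo in place of dimethylamino on an aromatic carbon. For the measured compounds named here, no measured step makes this exact exchange, and no measured compound has bromo at that place. The closest evidence is what separates compound 3, the only one with dimethylamino, from the others: a 2.5-fold higher number from compound 1 to compound 3 (0.40 log units; beyond the scatter) and a 2.1-fold higher number from compound 2 to compound 3 (0.32 log units; beyond the scatter), both modest. Read in reverse, these suggest that losing dimethylamino could bring a modest move to a lower number, though bromo itself remains untested there. The expected step is a 2.1-fold lower number from compound 3 to compound 4 (0.32 log units; beyond the scatter). Compound 4 is estimated at 12000 nM, with an expected range from 5000 nM to 25000 nM.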

Compound 4, half-maximal inhibitory concentration: 5600 nM
For compound 4 the middle estimate is 2.1-fold (0.33 log units) above the measured one, and the stated range covers the measured number.
By their numbers in this assay, from the lowest: compounds 4, 1 and 2 (each within the scatter of the next, the first and the last beyond it); then compound 3.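

In this assay the exchange at this place gives a 4.5-fold lower number from compound 3 to compound 4 (0.65 log units; beyond the scatter) and so shows that the higher number seen with dimethylamino does not carry over to bromo, the first group tried here other than dimethylamino and methoxy on this carbon. Against the 3,4-dimethoxyphenyl compound the result is a 2.1-fold lower number from compound 2 to compound 4 (0.33 log units; beyond the scatter) and also lies beyond the scatter, whereas a 1.8-fold lower number from compound 1 to compound 4 (0.25 log units; within the scatter) stays within it, so bromo and a single methoxy cannot be told apart at this place. No measurement bearing on why these groups differ is available.

The compounds shown leave open whether a smaller halogen such as fluoro or chloro would match bromo at this place. They also leave open how a primary amine or a carboxylic acid on the same carbon would compare with dimethylamino.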